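The source may report more compounds than this note shows. Statements on the series, on what has been measured and on what is new or still open speak of the compounds shown alone.

Three compounds have been tested in an assay on HEK293 cells for inhibition of Voltage-dependent T-type calcium channel subunit alpha-1G (Homo sapiens), read by patch clamp; a lower number here means a stronger inhibitor, a higher number a weaker inhibitor:

Compound 1 `COc1ccc(CNC(=O)CC2c3ccccc3N=C(N(C)CCCCCN(C)C)N2c2ccc(-c3ccccc3)cc2)cc1`: 390 nM
Compound 2 `CN(C)CCCCCN(C)C1=Nc2ccccc2C(CC(=O)NCc2ccccc2)N1c1ccc(-c2ccccn2)cc1`: "not determined" (no result reported)
Compound 3 `CN(C)CCCCN(C)C1=Nc2ccccc2C(CC(=O)NCc2ccccc2)N1c1ccc(-c2ccccc2)cc1`: 310 nM

Among the compounds with values here, only two numbers exist, and those of compound 1 and compound 3 lie within the usual scatter of each other, so neither compound is set apart in this assay. Compound 2 adds nothing, since it has no result.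

Compound 4 `COc1ccc(CNC(=O)CC2c3ccccc3N=C(N3CCN(CCN(C)C)CC3)N2c2ccc(-c3ccccc3)cc2)cc1` differs from compound 1 in one place: 4-(2-(dimethylamino)ethyl)piperazin-1-yl in place of (5-(dimethylamino)pentyl)(methyl)amino on a carbon with a double bond to nitrogen. Within the data shown here, no pair among the measured compounds shows a change of this kind, so the two numbers give no direct guide. The closed ring with its three nitrogen atoms replaces an open chain at the same carbon; lacking any comparable step, the expected outcome for compound 4 is a step from compound 1 of about a 1.4-fold higher number from compound 1 to compound 4 (0.15 log units; within the scatter), which is within or barely beyond the scatter. Compound 4 is therefore estimated at 550 nM, with a likely range from 150 nM to 2000 nM.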

Compound 4, half-maximal inhibitory concentration: 310 nM
The estimate for compound 4 lay 1.8-fold (0.25 log units) above the measured number, within the range that was stated.
By their numbers in this assay, from the lowest: compounds 3, 4 and 1 (each within the scatter of the next).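

Putting 4-(2-(dimethylamino)ethyl)piperazin-1-yl in place of (5-(dimethylamino)pentyl)(methyl)amino gives a 1.3-fold lower number from compound 1 to compound 4 (0.10 log units; within the scatter) in this assay. At this carbon with a double bond to nitrogen, a group with a six-membered non-aromatic ring and the open chain are therefore not set apart, so the open chain is not required for a number in this range. Nothing available explains this result.

Going by these compounds, all the measured compounds end in dimethylamino, so what that amine contributes remains open. It is also unknown whether a morpholin-4-yl group, which has no such side chain, would fit at this carbon.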